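Swapping a long side chain for a single bromine

This account rests on a few compounds, and the source may have more. Where it says the series, first, only, none or still open, it means among the compounds named here.

Compound 1 `CCCCCCOc1ccc2c(c1)C=C(CN(O)C(N)=O)CO2` inhibits the target in an assay (Cavia porcellus) for inhibition of Polyunsaturated fatty acid 5-lipoxygenase (Homo sapiens) (on this read-out lower numbers stand for stronger inhibition and higher numbers for weaker inhibition), with 340 nM, the highest number among the three measured compounds. Compound 2 `NC(=O)N(O)CC1=Cc2cc(OCCCc3ccccc3)ccc2OC1` gives 160 nM, and compound 3 `CC(C)NC(=O)N(O)CC1=Cc2cc(Oc3ccccc3)ccc2OC1` gives 63 nM. Compound 4 `NC(=O)N(O)CC1=Cc2cc(Br)ccc2OC1` differs from compound 1 by bromo in place of hexyloxy on an aromatic carbon. Within the data shown here, the only single-change step measured, a 2.1-fold lower number from compound 1 to compound 2 (0.33 log units; beyond the scatter), alters the end of that same side chain rather than removing it, so it bears on the new change only loosely; compound 3 differs from compound 1 in two places. As far as these compounds go, removing the side chain altogether is untested here, so the expectation rests on the step from compound 1 to compound 2 alone and carries wide uncertainty. Compound 4 is expected to show a weaker result, a step of a 2.9-fold higher number from compound 1 to compound 4 (0.47 log units; beyond the scatter), giving an estimated 1000 nM with a range from 300 nM to 4000 nM.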

Compound 4, half-maximal inhibitory concentration: 1400 nM
Compound 4: middle estimate off by 1.4-fold (0.15 log units), on the low side; low and high end bracket the measured number.
By their numbers in this assay, from the lowest: compound 3; then compound 2; then compound 1; then compound 4.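

Putting bromo in place of hexyloxy on this aromatic carbon gives a 4.1-fold higher number from compound 1 to compound 4 (0.61 log units; beyond the scatter), so a single bromine does not match the long side chain here. The earlier step changed only the end of that chain, whereas this one shows what happens when the whole chain goes: the number rises, although the step is modest. Nothing measured here explains the shift. As far as these compounds go, whether a short methoxy group or an amine would land nearer compound 1 or compound 4 stays open. A plain hexyl chain could separate the effect of chain length from that of the oxygen on the aromatic ring.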